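Swapping a phenyl for pyridin-2-yl on a diamine scaffold

A few compounds are considered here, and "the series" means these few. Any claim that something is new, unique, unknown or untested is made for them only; others in the source may bear on it.

Of the compounds shown here, three built on one shared core have been tested in a functional assay on MDA-MB-231 cells for antagonist activity at C-X-C chemokine receptor type 4 (Homo sapiens), tested at 10 nM; a lower number here means a weaker effect, a higher number a stronger effect of the compound at the concentration tested. Compound 1 `c1ccc(NCc2ccc(CNc3ccccc3)cc2)cc1` gives 54% in this assay. Compound 2 `Fc1ccccc1NCc1ccc(CNc2ccccc2F)cc1`, which carries fluorine atoms on both outer rings, gives 32% in this assay. Compound 3 `c1ccc(NCc2ccc(CNc3ncccn3)cc2)cc1` gives 55% in this assay, the highest of the three numbers; it sits within the scatter of compound 1 and beyond the scatter above compound 2. Within the data shown here, the one single-point step measured so far, a number 1 percentage points higher from compound 1 to compound 3 (within the scatter), shows that replacing phenyl with pyrimidin-2-yl on an amine nitrogen left the read-out essentially unchanged.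

Compound 4 `c1ccc(NCc2ccc(CNc3ncccn3)cc2)nc1` takes the same kind of step on the other side of the molecule: pyridin-2-yl in place of phenyl on an amine nitrogen. Among the measured compounds shown here, the only measured step that bears on this change is the one from compound 1 to compound 3, and it was within the scatter, so a similar swap of phenyl for a nitrogen-containing six-membered ring is expected to leave this assay about where it is. On that basis compound 4 is expected to give 54% in this assay, with a likely range from 40% to 68%. The expected step is therefore a number 1 percentage points lower from compound 3 to compound 4 (within the scatter), nothing beyond the scatter.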

Compound 4, a percentage reported as inhibition, at one concentration (the size of the read-out at that concentration, not a potency): 58%
Estimate against measurement, compound 4: 4 percentage points below; measured number inside the range.
By their numbers in this assay, from the lowest: compound 2; then compounds 1, 3 and 4 (each within the scatter of the next).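

In this assay the step of a number 3 percentage points higher from compound 3 to compound 4 (within the scatter) now stands with the earlier step of a number 1 percentage points higher from compound 1 to compound 3 (within the scatter) and so each of the two phenyl groups on an amine nitrogen in compound 1 has been exchanged in turn, with neither single exchange going beyond the usual scatter. The earlier compounds shown here showed this only for pyrimidin-2-yl, whereas this result shows that pyridin-2-yl is also tolerated in this assay, and that it is tolerated in a molecule that already carries pyrimidin-2-yl on its other amine nitrogen. Nothing measured alongside these numbers offers an explanation for this tolerance.

The compounds shown leave open how far this tolerance extends, for instance whether a saturated ring such as piperidine, or a phenyl bearing a carboxylic acid, would hold the number at the same level on that amine nitrogen. They also leave open how the fluorine atoms of compound 2 act, since that compound differs from compound 1 in two places and a molecule with a single 2-fluorophenyl group would be needed to separate the two sides.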